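Compound 1 to compound 4: swapping chlorine for fluorine

The compounds below may be only part of what the source reports. "The series", "measured", "known", "first", "only" and "open" are said of these compounds alone.

compound 1 `CO[C@H]1CC[C@H](NC(=O)c2n[nH]cc2NC(=O)c2cc(Cl)cc(Cl)c2)CC1`: 13000 nM
compound 2 `COc1cccc(OC)c1C(=O)Nc1c[nH]nc1C(=O)NC1CCN(C(=O)OC(C)(C)C)CC1`: > 50000 nM (a limit)
compound 3 `COc1cc(OC)c(C(=O)Nc2c[nH]nc2C(=O)N[C@H]2CC[C@H](OC)CC2)c(OC)c1`: > 50000 nM (a limit)

Going by the values given here, in an ADME assay on MRC5 cells (Homo sapiens) for inhibition, with a stated time of 72 h (a higher number here means that more compound is needed for the effect, a lower number that less compound is needed), compound 1 gives the only true number (13000 nM). Compound 2 shows a limit of the assay, not a number (> 50000 nM). Compound 3 likewise shows a limit (> 50000 nM).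

Compound 4 `CO[C@H]1CC[C@H](NC(=O)c2n[nH]cc2NC(=O)c2cc(F)cc(F)c2)CC1` keeps the core of compound 1 and has 3,5-difluorophenyl in place of 3,5-dichlorophenyl on a carbonyl carbon. Among the compounds with values here, no measured pair shows this swap, so the step in this assay is a judgement. A moderate rise is expected, as compound 1 alone carries chlorine and alone gives a number (13000 nM). The expected step is a 2.5-fold higher number from compound 1 to compound 4 (0.39 log units; beyond the scatter). For compound 4 the estimated value is 32000 nM, with an expected range from 13000 nM to 60000 nM.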

Compound 4, half-maximal effective concentration: 600 nM
Estimate against measurement, compound 4: 53-fold (1.73 log units) above, outside the stated range (below it).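

Swapping 3,5-dichlorophenyl for 3,5-difluorophenyl on a carbonyl carbon gives a 22-fold lower number from compound 1 to compound 4 (1.34 log units; beyond the scatter) in this assay. With the rest of the molecule unchanged, this single group clearly has a large effect on how much compound is needed. Compounds 2 and 3 give only a limit of the assay, not a number, so they offer no step of this kind: the limit of > 50000 nM in this assay, at which 2 of the 4 values shown sit.

What lies behind the step remains open. So does how an unsubstituted phenyl or a 3,5-dimethylphenyl would behave in the same place on the core of compound 1.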